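Methyl for fluoro on the arylidene ring across two cores

This account rests on a few compounds, and the source may have more. Where it says the series, first, only, none or still open, it means among the compounds named here.

Compound 1 `O=C1/C(=C/c2ccc(F)cc2)Cc2ccccc21` and compound 2 `Cc1ccc(/C=C2\Cc3ccccc3C2=O)cc1` share one core; compound 3 `O=C1/C(=C/c2cccc(F)c2)CCc2ccccc21` and compound 4 `Cc1cccc(/C=C2\CCc3ccccc3C2=O)c1` share another, and the difference between the two cores is not broken down here. In a functional assay on MOLT-4 cells (Homo sapiens) for inhibition (a lower number here means a stronger inhibitor, a higher number a weaker inhibitor), compound 1 gives 60000 nM. Compound 2 reaches only a limit of the assay, > 500000 nM. The step of an at least 8.3-fold higher number from compound 1 to compound 2 (0.92 log units; beyond the scatter) is the change (methyl in place of fluoro on an aromatic carbon); its size is known only as a lower bound because of the limit of > 500000 nM in this assay, at which 1 of the 3 values shown sits. In this assay, going by the values given here, compound 3 gives 11900 nM, the lowest of the two numbers so far. Compound 4 is not yet measured; it differs from compound 3 by methyl in place of fluoro on an aromatic carbon, the same kind of change as from compound 1 to compound 2 but not the same, since in compound 2 the methyl sits para to a large group and in compound 4 it sits meta to a large group. Resting on the step of an at least 8.3-fold higher number from compound 1 to compound 2 (0.92 log units; beyond the scatter), a weakening of similar order is expected, a 6.7-fold higher number from compound 3 to compound 4 (0.83 log units; beyond the scatter), though the different surroundings of the change leave the size uncertain. Compound 4 is therefore estimated at 80000 nM, between 20000 nM and 500000 nM.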

Compound 4, half-maximal inhibitory concentration: 35800 nM
Beside the measured number, compound 4's estimate is 2.2-fold (0.35 log units) above it; low and high end bracket the measured number.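

In this assay the change again gives a higher number on the second core, a 3.0-fold higher number from compound 3 to compound 4 (0.48 log units; beyond the scatter), so its direction carries over from the core of compound 1 to the core of compound 3 in these two pairs. Its size does not carry over as a fixed amount, and these two pairs cannot show whether the core or the place of the change on the aromatic ring sets the gap: the same change on two cores in this assay, an at least 8.3-fold higher number (0.92 log units; beyond the scatter) from compound 1 to compound 2 and a 3.0-fold higher number (0.48 log units; beyond the scatter) from compound 3 to compound 4, at least 2.7-fold (0.44 log units) apart, beyond the scatter of two such steps. As far as these compounds go, compound 2 stands at a limit of the assay, so the earlier step is known only as a lower bound and the true gap remains unknown: the limit of > 500000 nM in this assay, at which 1 of the 4 values shown sits.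

The compounds shown leave open how the step reads with fluoro and methyl at the same place on the aromatic ring in both cores. Also open, from the compounds shown here alone, is how an amine or a carboxylic acid at that place would read in this assay on either core.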